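Cyanomethyl replaced on compound 1 — an expected gain

The source may hold more compounds than are shown below. What is called first, only, known or untested is meant among the compounds shown, and "the series" means these compounds.

Compound 1, `N#CCCn1nc(-c2ccccc2)ccc1=O`, gives 10.1% in a functional assay on the whole organism (stomach) for inhibition, with Rattus norvegicus as the target, at a dose of 100 mg/kg by the intraduodenal route; on this read-out higher numbers stand for more inhibition at the one dose given (going by the name of the read-out) and lower numbers for less inhibition. Compound 2, `N=C(S)CCN1N=C(c2ccccc2)CCC1=O`, gives 38.2% in this assay. Compound 1 therefore stands lowest of the two numbers, and its nearest neighbour, compound 2, lies higher by a margin beyond the scatter. The two differ in more than one place, so their numbers can only be set side by side.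

Compound 3, `N=C(S)Cn1nc(-c2ccccc2)ccc1=O`, is not yet measured. It differs from compound 1 in one place: a group of 3 heavy atoms (1 carbon, 1 nitrogen, 1 sulfur; no ring) in place of a group of 3 heavy atoms (2 carbon, 1 nitrogen; no ring), on a saturated chain carbon bound to an aromatic nitrogen. For the measured compounds named here, the group that enters is of the same kind as the one compound 2 bears on its own chain. Because compound 2 gives 38.2%, the step expected here, a number 15.9 percentage points higher from compound 1 to compound 3 (beyond the scatter), is upward and beyond the scatter. Compound 3 is estimated to give 26%, with a range from 8% to 45%.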

Compound 3, a percentage reported as inhibition, in the whole organism at one dose (the size of the read-out at that dose, not a potency): 5.5%
The estimate for compound 3 lay 20.5 percentage points above the measured number; measured number below the stated range.
By their numbers in this assay, from the lowest: compounds 3 and 1 (each within the scatter of the next); then compound 2.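

For the compounds shown here, this pair is the first in the set to differ in one place only. In this assay the exchange of cyanomethyl for the sulfur-bearing group, on a saturated chain carbon bound to an aromatic nitrogen, gives a number 4.6 percentage points lower from compound 1 to compound 3 (within the scatter), so this read-out does not tell the two groups apart at this place on the core of compound 1. Nothing at hand offers a reason for this result.

The compounds shown leave open whether the sulfur-bearing group would behave differently on a longer chain or on the core of compound 2, since compound 2 differs from compound 3 in more than one place. As far as these compounds go, what an amine or a carboxylic acid would give at this place also remains unknown.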